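Swapping the Chain-End Ring on a Weakly Cytotoxic Pair

The compounds below may be only part of what the source reports. "The series", "measured", "known", "first", "only" and "open" are said of these compounds alone.

Compound 1, `Cc1nc(Nc2ccccc2)sc1C(=O)/C=C/c1ccc(Cl)cc1`: in a functional assay on PC-3 cells (Homo sapiens) for cytotoxicity, read by MTT assay (on this read-out lower numbers stand for stronger inhibition and higher numbers for weaker inhibition), compound 1 gives > 25000 nM, which is a limit of the assay.
Compound 2, `Cc1nc(Nc2ccc(Cl)c(Cl)c2)sc1C(=O)/C=C/c1ccc(Cl)cc1`: in this assay compound 2 gives > 25000 nM, likewise a limit.

Compound 2 therefore stands only at a limit, and the step that the two limits leave unreadable from compound 1 to compound 2 cannot be sized; both values sit at the limit of > 25000 nM in this assay, at which 2 of the 2 values shown sit. Compound 3, `COc1cccc(/C=C/C(=O)c2sc(Nc3ccc(Cl)c(Cl)c3)nc2C)c1`, carries 3-methoxyphenyl in place of 4-chlorophenyl on a double-bonded chain carbon bound to a double-bonded chain carbon. No measured step touches this chain-end ring, so nothing shown predicts a change, and compound 3 is expected to stay near the limit. The estimate for compound 3 is 30000 nM (8000 nM to 100000 nM), an expected step that the limit leaves unreadable from compound 2 to compound 3.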

Compound 3, half-maximal inhibitory concentration: 10100 nM
For compound 3 the middle estimate is 3.0-fold (0.47 log units) above the measured one; measured number inside the range.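

In this assay, changing the ring at the end of the chain moves the read-out: 3-methoxyphenyl in place of 4-chlorophenyl gives an at least 2.4-fold lower number from compound 2 to compound 3 (0.39 log units; beyond the scatter). Compound 3 alone of the three gives a number rather than a limit, so this position responds to change, whereas the earlier pair showed no readable step. The full size of this step cannot be read, because compound 2 stands only at a limit: the limit of > 25000 nM in this assay, at which 2 of the 3 values shown sit.

Going by these compounds, it remains open whether the lower number comes from adding the methoxy group or from losing the chlorine. On these data alone, it is also open whether an amine or a carboxylic acid on this ring would lower the number further.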